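This account rests on a few compounds, and the source may have more. Where it says the series, first, only, none or still open, it means among the compounds named here.

Measured so far:
compound 1, `COc1ccc(/C=N/NC(=S)N/N=C2\C(=O)Nc3ccc(C)cc32)cc1O`: 3190 nM
compound 2, `Cc1ccc(O)c(/C=N/NC(=S)N/N=C2\C(=O)Nc3ccc(Br)cc32)c1`: > 50000 nM

In a functional assay on COS-7 cells (Chlorocebus aethiops) for inhibition, read by MTT assay (on this read-out higher numbers stand for weaker inhibition and lower numbers for stronger inhibition), compound 1 gives 3190 nM. For compound 2 the assay returns only a limit, > 50000 nM, so its place among the numbers shown stays open. It sits at the limit of > 50000 nM in this assay, at which 1 of the 2 values shown sits, and how far past that point it lies is not told. Compound 3, `Cc1ccc(O)c(/C=N/NC(=S)N/N=C2\C(=O)Nc3ccc(C)cc32)c1`, follows from compound 2 by methyl in place of bromo on an aromatic carbon. Going by the values given here, no single step between measured compounds is at hand for this change; compound 1, which also carries a methyl on its core, gives a number where compound 2 gives only a limit, though compound 1 differs from compound 3 in the other aryl part as well. Compound 3 is expected to move toward stronger inhibition, a step of an at least 3.3-fold lower number from compound 2 to compound 3 (0.52 log units; beyond the scatter), with a real chance that this assay again reports only a limit. The estimate for compound 3 is 15000 nM, with a range from 3000 nM to 100000 nM.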

Compound 3, half-maximal inhibitory concentration: > 50000 nM
Compound 3 was reported as a limit (the forecaster's own chance of this, stated with the estimate: 40%); middle value at least 3.3-fold (0.52 log units) from the limit.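

In this assay, 2-hydroxy-5-methylphenyl in place of 3-hydroxy-4-methoxyphenyl on the carbon with a double bond to nitrogen, with the methyl on the core kept, gives an at least 15-fold higher number from compound 1 to compound 3 (1.19 log units; beyond the scatter), so this aryl part matters a great deal in this series. The step for methyl in place of bromo on the aromatic carbon cannot be read, as both of its ends are limits. With the 2-hydroxy-5-methylphenyl part in place, neither bromo nor methyl at this position gives a number, and compound 2 and compound 3 both stop at the assay's limit: the limit of > 50000 nM in this assay, at which 2 of the 3 values shown sit.

From the compounds shown here alone, it remains open how far past that limit compound 2 and compound 3 lie, and whether they differ from each other. Also open, going by these compounds, is whether an amine or a carboxylic acid on this aromatic carbon would give a number with this aryl part, and how bromo would fare alongside the 3-hydroxy-4-methoxyphenyl part.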